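The compounds below may be only part of what the source reports. "The series", "measured", "known", "first", "only" and "open" are said of these compounds alone.

Measured compounds:
- compound 1, `Cc1ccc(-n2nc(C(C)(C)C)cc2NC(=O)Nc2cccc(Oc3ccnc4[nH]c(=O)cnc34)c2)cc1`: 4 h
- compound 2, `Cc1ccc(-n2nc(C(C)(C)C)cc2NC(=O)Nc2ccc(Oc3ccnc4[nH]c(=O)cnc34)cc2)cc1`: 6.3 h

In an in vivo ADME assay on the whole organism (strain C57BL/cAnNCrl) for metabolic stability, with Mus musculus as the target, at a dose of 10 mg/kg by the oral route (on this read-out higher numbers stand for a longer-lived compound and lower numbers for a shorter-lived compound), compound 1 gives 4 h and compound 2 gives 6.3 h. Within the data shown here, the two numbers sit at either end of the small set, with compound 1 at one end and compound 2 at the other, and the gap between them lies within the usual scatter of repeated measurements, so nothing can be read from it; no step between these two is recorded, and only the two values themselves are known.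

The next compound, compound 3, `CC(C)(C)c1cc(NC(=O)Nc2cccc(Oc3ccnc4[nH]c(=O)cnc34)c2)n(-c2ccccc2)n1`, is not yet measured in this assay. Set against compound 1 it differs in one place: hydrogen in place of methyl on an aromatic carbon. The change removes a single carbon atom without touching the urea, the ether link or the shared core, and adds or removes no donor or acceptor.

With no measured step of this kind in the series, the expected step from compound 1 to compound 3 is no change at the digits printed from compound 1 to compound 3 (within the scatter), that is, none beyond the scatter. Compound 3 is therefore estimated to give 4 h, with a range from 2 h to 8 h.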

Compound 3, half-life: 1.4 h
Compound 3: the middle estimate sits 2.9-fold (0.46 log units) above what was measured, outside the stated range (below it).
By their numbers in this assay, from the lowest: compound 3; then compounds 1 and 2 (each within the scatter of the next).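

In this assay, among these compounds, the change from 4-methylphenyl to phenyl gives a 2.9-fold lower number from compound 1 to compound 3 (0.46 log units; beyond the scatter), the first step that can be read beyond the scatter. This shows that the aromatic carbon para to a large group is not a silent position on this read-out: replacing methyl with hydrogen is enough to shorten the half-life, with the urea, the ether link and the shared core unchanged. No measurement here bears on the reason for the shorter half-life, so the step stands as an observation only.

Open, going by these compounds, is whether the same change on compound 2 gives a step of like size, since a single pair cannot show whether the effect holds beyond the core arrangement of compound 1. Also open, on these data alone, is how specific the result is to methyl: ethyl, methoxy, chlorine or trifluoromethyl at the same aromatic carbon would show whether other groups match compound 1 or fall closer to compound 3.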